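Adding methylsulfonyl to the phenyl ring of compound 2

This account rests on a few compounds, and the source may have more. Where it says the series, first, only, none or still open, it means among the compounds named here.

Compound 1 `C[C@H]1[C@H](NC(=O)OCCCCC2CCCCC2)C(=O)N1OCCCS(C)(=O)=O`: < 0.0834 h
Compound 2 `C[C@H]1[C@H](NC(=O)OCCCCC2CCCCC2)C(=O)N1Oc1ccccc1`: < 0.0834 h

In an ADME assay on a cell-free system (plasma, Mus musculus) for metabolic stability, read by LC-MS, with a stated time of 2 h, tested at 2 uM (on this read-out lower numbers stand for a shorter-lived compound and higher numbers for a longer-lived compound), compound 2 gives < 0.0834 h, which is a limit and not a number. The record so far is the limit of < 0.0834 h in this assay, at which 2 of the 2 values shown sit.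

Compound 3 `C[C@H]1[C@H](NC(=O)OCCCCC2CCCCC2)C(=O)N1Oc1ccc(S(C)(=O)=O)cc1` has methylsulfonyl in place of hydrogen on an aromatic carbon, para to a large group, turning phenyl into 4-(methylsulfonyl)phenyl: methylsulfonyl in place of hydrogen on an aromatic carbon.

Among the compounds with values here, only one measured step bears on this: a step that the two limits leave unreadable from compound 1 to compound 2. It gives no size to carry over. The expectation therefore rests on a single observation. Compound 1 carries methylsulfonyl within its 3-(methylsulfonyl)propyl group and still gives < 0.0834 h, also a limit. No step beyond the scatter is expected in this assay, in either direction, and the assay will probably report only a limit again. The expected change is a step that the limit leaves unreadable from compound 2 to compound 3. The estimate for compound 3 is 0.06 h, within an expected range of 0.02 h to 0.17 h.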

Compound 3, half-life in the plasma assay: < 0.0834 h
Compound 3 was reported as a limit; the forecaster's own chance of this, stated with the estimate: 85%; the middle value is on the limit's open side.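

In the plasma assay compound 1 gives < 0.0834 h, which is a limit and not a number. In the plasma assay compound 2 gives < 0.0834 h, also a limit. Within the data shown here, in the plasma assay compound 3 gives < 0.0834 h, again a limit, and no step between the three compounds can be read. The compounds shown leave open how long any of the three actually lasts in the plasma assay, and whether methylsulfonyl in place of hydrogen changes that. In a physicochemical assay for metabolic stability, read by HPLC, in phosphate buffer, with a stated time of 24 h, at 37 degrees C, at pH 7.4, tested at 1 uM, in the presence of a further agent that is not named here (a lower number here means that the compound disappears faster, a higher number that the compound lasts longer), compound 2 gives > 24 h, which is a limit and not a number. In the physicochemical assay compound 3 gives 12.1 h.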